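Swapping a Ring-Nitrogen Cap: Sulfonyl to Ester

A few compounds are considered here, and "the series" means these few. Any claim that something is new, unique, unknown or untested is made for them only; others in the source may bear on it.

Compound 1, `CCN(CC)c1ccc2cc(C(=O)c3ccc(N4CCN(C(=O)CN5CCN(C(=O)/C=C/c6ccccc6)CC5)CC4)cc3)oc2c1`: 5260 nM in a functional assay on HeLa cells (Homo sapiens) for cytotoxicity, read by MTT assay, with a stated time of 48 h; a lower number here means a stronger inhibitor, a higher number a weaker inhibitor
Compound 2, `CCN(CC)c1ccc2cc(C(=O)c3ccc(N4CCN(C(=O)CN5CCN(S(=O)(=O)C6CC6)CC5)CC4)cc3)oc2c1`: 28100 nM in this assay

Going by the values given here, compound 2 stands highest of the two numbers measured so far; the single measured step, a 5.3-fold higher number from compound 1 to compound 2 (0.73 log units; beyond the scatter), separates it from its only neighbour. Compound 3, `CCOC(=O)CN1CCN(CC(=O)N2CCN(c3ccc(C(=O)c4cc5ccc(N(CC)CC)cc5o4)cc3)CC2)CC1`, differs from compound 2 by (ethoxycarbonyl)methyl in place of cyclopropylsulfonyl on an amine nitrogen in a ring. The measured step is the one that bears here, since it also changed the group on the same ring nitrogen, and it was modest in size. It tells size but not direction for a fresh cap, so a modest step, more likely downward, is expected. Compound 3 is expected to give 14000 nM, with a range from 4000 nM to 45000 nM. That estimate means an expected step of a 2.0-fold lower number from compound 2 to compound 3 (0.30 log units; within the scatter).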

Compound 3, half-maximal inhibitory concentration: 22100 nM
Compound 3: the middle estimate sits 1.6-fold (0.20 log units) below what was measured, and the stated range covers the measured number.
By their numbers in this assay, from the lowest: compound 1; then compounds 3 and 2 (each within the scatter of the next).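

In this assay, the (ethoxycarbonyl)methyl and cyclopropylsulfonyl caps on this ring nitrogen cannot be told apart, with a 1.3-fold lower number from compound 2 to compound 3 (0.10 log units; within the scatter) as the step. Only the cyclopropylsulfonyl cap has a ring, yet the two read alike, while the (2-phenylethenyl)carbonyl cap stays apart, with a 4.2-fold higher number from compound 1 to compound 3 (0.62 log units; beyond the scatter) as the step. No measurement at hand accounts for either step. Still open, going by these compounds, is how this position would read with a cap carrying a free carboxylic acid, a simple amine or a longer chain.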